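From Butoxy to Methoxy, Starting Without a Number

A few compounds are considered here, and "the series" means these few. Any claim that something is new, unique, unknown or untested is made for them only; others in the source may bear on it.

- Compound 1 `CCCCOc1cc(C)c(-c2cccc(COc3ccc(OCC(=O)O)c(F)c3)c2)c(C)c1`: "not determined" (no result reported)
- Compound 2 `Cc1cc(OCCCS(C)(=O)=O)ccc1-c1cccc(COc2ccc(OCC(=O)O)c(F)c2)c1`: 1.63

This piece concerns how strongly these compounds favour the oily phase over the watery one, as read in a physicochemical assay for lipophilicity, using the shake flask method, in phosphate buffer, measured as octanol-water partition, with a stated time of 24 h, at pH 7.4, tested at 100 uM; on this read-out higher numbers stand for higher lipophilicity and lower numbers for lower lipophilicity. In this assay, going by these compounds, compound 1 gives "not determined" (no result reported), so it has no place on the scale, and the starting point of the step is unknown. Within the data shown here, the only number available comes from compound 2, which gives 1.63.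

The next compound to be tested is compound 3 `COc1cc(C)c(-c2cccc(COc3ccc(OCC(=O)O)c(F)c3)c2)c(C)c1`. The structural change is hydrogen in place of propyl on a saturated chain carbon bound to an oxygen on an aromatic ring: butoxy to methoxy, or hydrogen in place of propyl on a saturated chain carbon bound to an oxygen on an aromatic ring. The rest of the structure stays the same. Among the measured compounds shown here, no measured pair shows what such a change does here. Even so, a moderate downward step beyond the usual scatter is expected in this assay, though it cannot be checked without a number for compound 1. The estimate therefore rests on a single measured value, so its range is kept wide. For compound 3 the expected value is 2.3, with an estimated range from 1.7 to 2.9.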

Compound 3, distribution coefficient: 3.2
For compound 3 the middle estimate is 0.90 log units below the measured one; measured number above the stated range.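

In this assay, among these compounds, compound 1 gives "not determined" (no result reported) and compound 3 gives 3.2 and so no step between compound 1 and compound 3 can be read. The compounds shown leave open how far the change from butoxy to methoxy moves the value on this scale. Nothing measured here offers an explanation for the value of compound 3.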